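The compounds below may be only part of what the source reports. "The series", "measured", "known", "first", "only" and "open" are said of these compounds alone.

Measured so far, in a functional assay on KOPN-8 cells (Homo sapiens) for antiproliferative activity, with a stated time of 72 h; a higher number here means that more compound is needed for the effect, a lower number that less compound is needed:
compound 1 `COc1ccc(-c2cc(=O)c3c(OC)cc(OC)cc3[nH]2)cc1`: > 31100 nM
compound 2 `COc1ccc(-c2cc(=O)c3c(OC)cc(OC)cc3n2Cc2ccccc2)cc1`: > 17300 nM
compound 3 `COc1ccc(-c2c(I)c(=O)c3c(OC)cc(OC)cc3n2S(=O)(=O)c2ccc(OC)cc2)cc1`: 8580 nM

Compound 2 gives only a limit in this assay, > 17300 nM. Compound 1 likewise gives only a limit, > 31100 nM. The step that the two limits leave unreadable from compound 1 to compound 2 is therefore unreadable. Going by the values given here, compound 3, the one compound with a number, gives 8580 nM; it differs from compound 2 in two places, so no single step can be read from it.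

Compound 4 `COc1ccc(-c2cc(=O)c3c(OC)cc(OC)cc3n2S(=O)(=O)c2ccc(C=O)cc2)cc1` carries the change ((4-formylphenyl)sulfonyl in place of benzyl on an aromatic nitrogen). Among the compounds with values here, no measured step bears on this change, and compound 2 offers no number to start from. Compound 3 shows that an aryl sulfonyl on this nitrogen can come with a measurable value, so compound 4 is expected at 15000 nM, within 5000 nM to 50000 nM. The expected step is an at least 1.1-fold lower number from compound 2 to compound 4 (0.06 log units; that floor lies within the scatter).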

Compound 4, half-maximal effective concentration: > 34400 nM
Compound 4: only a limit was reported; the forecaster's own chance of this, stated with the estimate: 45%; middle value at least 2.2-fold (0.36 log units) from the limit.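

Compound 4 gives only a limit, > 34400 nM, and compound 1 and compound 2 are limits too, so its steps from both cannot be read. The compounds shown leave open whether (4-formylphenyl)sulfonyl on the aromatic nitrogen changes the value at all.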